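This account rests on a few compounds, and the source may have more. Where it says the series, first, only, none or still open, it means among the compounds named here.

Notes on the silyl series. The shared core is held constant; only the group on silicon changes. Among the compounds with values here, in an ADME assay on microsomes from liver (Homo sapiens) for metabolic stability, read by HPLC, using NADPH, with stated times of 5 min and 60 min, tested at 0.2 uM (a higher number here means that more of the compound is left, a lower number that less of the compound is left), compound 1 `COC(=O)N[C@H](C(=O)N1CCC[C@H]1C(=O)Nc1ccc([C@@H]2CC[C@@H](c3ccc(NC(=O)[C@@H]4CCCN4C(=O)[C@@H](NC(=O)OC)C(C)C)cc3)N2c2ccc([Si](C)(C)C)cc2)cc1)C(C)C` gives 99.2%, the higher of the two numbers measured so far. Compound 2 `CC[Si](CC)(CC)c1ccc(N2[C@H](c3ccc(NC(=O)[C@@H]4CCCN4C(=O)[C@@H](NC(=O)OC)C(C)C)cc3)CC[C@H]2c2ccc(NC(=O)[C@@H]3CCCN3C(=O)[C@@H](NC(=O)OC)C(C)C)cc2)cc1` gives 85.6% in this assay. Within the data shown here, the one measured step, a number 13.6 percentage points lower from compound 1 to compound 2 (beyond the scatter), goes with a larger silyl group on the aromatic carbon and is a modest loss that lies beyond the scatter.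

Compound 3 `COC(=O)N[C@H](C(=O)N1CCC[C@H]1C(=O)Nc1ccc([C@@H]2CC[C@@H](c3ccc(NC(=O)[C@@H]4CCCN4C(=O)[C@@H](NC(=O)OC)C(C)C)cc3)N2c2ccc([Si](C)(C)C(C)(C)C)cc2)cc1)C(C)C` is not yet measured. Its change from compound 1 is tert-butyl in place of methyl on a silicon. Among the measured compounds shown here, the only step that bears on it is the enlargement of the silyl group from compound 1 to compound 2; compound 3 enlarges the same group, and a loss of similar or somewhat smaller size is therefore expected, in the same direction, because of a number 13.6 percentage points lower from compound 1 to compound 2 (beyond the scatter). The estimate for compound 3 in this assay is 88% with a range of 75% to 98%, which means an expected step of a number 11.2 percentage points lower from compound 1 to compound 3 (beyond the scatter).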

Compound 3, percent of the compound remaining: 84.3%
Compound 3: the middle estimate sits 3.7 percentage points above what was measured; the measured number falls inside the stated range.
By their numbers in this assay, from the lowest: compounds 3 and 2 (each within the scatter of the next); then compound 1.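

In this assay, tert-butyl in place of methyl on a silicon gives a number 14.9 percentage points lower from compound 1 to compound 3 (beyond the scatter), so the loss seen with the first enlargement also appears when only one substituent on silicon is changed and the other two methyl groups stay. The silyl groups of compound 2 and compound 3 hold the same count of heavy atoms but are built differently, and a number 1.3 percentage points lower from compound 2 to compound 3 (within the scatter), so the two cannot be told apart in this assay. No measurement at hand explains the loss in either compound.

Still open, as far as these compounds go, is whether a phenyl or triisopropylsilyl group would lie with compound 2 and compound 3 or further down. Also open, from the compounds shown here alone, is how a carbon-centred tert-butyl on the aromatic carbon, without silicon, would compare with compound 1.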